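From Methyl to Chloro on a Shared Core

The source may report more compounds than this note shows. Statements on the series, on what has been measured and on what is new or still open speak of the compounds shown alone.

Compound 1 (`Cc1ccc(NCc2cn(-c3ccccc3)nc2-c2ccc(Cl)cc2)cc1`) gives 3480 nM in a functional assay on B16-F10 cells (Mus musculus) for antiproliferative activity, read by MTT assay, with a stated time of 48 h (a lower number here means a stronger inhibitor, a higher number a weaker inhibitor), and compound 2 (`Cc1ccc(-c2nn(-c3ccccc3)cc2CNc2ccc(Br)cc2)cc1`) gives 6760 nM there, so the two lie within the usual scatter of each other. Compound 3 (`Clc1ccc(-c2nn(-c3ccccc3)cc2CNc2ccc(Br)cc2)cc1`) differs from compound 2 by a single swap (chloro in place of methyl on an aromatic carbon), chloro in place of methyl on an aromatic carbon, which turns 4-methylphenyl into 4-chlorophenyl. Among the compounds with values here, no measured pair shows this swap alone. Since compound 1 with its 4-chlorophenyl gives 3480 nM and stays within the scatter of compound 2, no step beyond the scatter is expected in this assay here. Compound 3 is estimated at 4500 nM with an expected range from 1800 nM to 11000 nM on this reasoning.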

Compound 3, half-maximal inhibitory concentration: 3010 nM
The estimate for compound 3 lay 1.5-fold (0.17 log units) above the measured number, within the range that was stated.
By their numbers in this assay, from the lowest: compounds 3, 1 and 2 (each within the scatter of the next, the first and the last beyond it).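

Chloro in place of methyl on this aromatic carbon gives a 2.2-fold lower number from compound 2 to compound 3 (0.35 log units; beyond the scatter) in this assay and is the first single swap here to pass beyond the scatter, though only modestly. Bromo, entering where compound 1 carries methyl, gives a 1.2-fold lower number from compound 1 to compound 3 (0.06 log units; within the scatter) and stays within the scatter, so that change shows no readable effect. Nothing measured here bears on the reason for either result. On these data alone, whether an amine or a carboxylic acid in this place would shift the number further remains open. Within the data shown here, with only one pair testing the chloro swap, whether it holds elsewhere on the shared core is also unknown.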